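Swapping the Benzylic Aryl Group in a Weak Antiproliferative Series

This account rests on a few compounds, and the source may have more. Where it says the series, first, only, none or still open, it means among the compounds named here.

Compound 1 `COc1cc(N(Cc2ccc(C)cc2)C(=O)CSc2nc3ccccc3s2)cc(OC)c1OC`: > 80000 nM
Compound 2 `COc1cc(CN(C(=O)CSc2nc3ccccc3s2)c2cc(OC)c(OC)c(OC)c2)cc(OC)c1OC`: 65300 nM

In a functional assay on HCT-116 cells (Homo sapiens) for antiproliferative activity, read by MTT assay, with a stated time of 48 h (on this read-out higher numbers stand for weaker inhibition and lower numbers for stronger inhibition), compound 1 gives only a limit, (the limit of > 80000 nM in this assay, at which 1 of the 2 values shown sits). For the measured compounds named here, compound 2 gives 65300 nM, the only full number here, so it is weakly active. Compound 3 `COc1ccc(CN(C(=O)CSc2nc3ccccc3s2)c2cc(OC)c(OC)c(OC)c2)cc1N` changes the aryl group at the same place as before: 3-amino-4-methoxyphenyl in place of 3,4,5-trimethoxyphenyl on a saturated chain carbon bound to an amide-type nitrogen. Going by the values given here, only the step of an at least 1.2-fold lower number from compound 1 to compound 2 (0.08 log units; that floor lies within the scatter) bears on this change, and it lay within the scatter, so for compound 3 a step of a 1.1-fold lower number from compound 2 to compound 3 (0.04 log units; within the scatter) is expected, none beyond the scatter. Compound 3 is therefore estimated at 60000 nM, between 20000 nM and 90000 nM.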

Compound 3, half-maximal inhibitory concentration: 491 nM
Beside the measured number, compound 3's estimate is 120-fold (2.09 log units) above it, outside the stated range (below it).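

Compared with the earlier swap at this place, which stayed within the scatter, the aryl group on a saturated chain carbon bound to an amide-type nitrogen now proves decisive in this assay: 3-amino-4-methoxyphenyl in place of 3,4,5-trimethoxyphenyl gives a 130-fold lower number from compound 2 to compound 3 (2.12 log units; beyond the scatter). Replacing 4-methylphenyl with the same group gives an at least 160-fold lower number from compound 1 to compound 3 (2.21 log units; beyond the scatter). Compound 1 gives only a limit, so that second step is a floor.

The compounds shown leave open whether a hydroxyl group or an acetamide in place of the amine would keep this activity. Nothing measured here explains why this change has so large an effect.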